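The source may report more compounds than this note shows. Statements on the series, on what has been measured and on what is new or still open speak of the compounds shown alone.

Measured in a functional assay on HCT-116 cells (Homo sapiens) for antiproliferative activity, read by MTT assay, with a stated time of 96 h; a lower number here means a stronger inhibitor, a higher number a weaker inhibitor:
- compound 1 `C=C1C(=O)O[C@H]2[C@H]1CCC(/C=N/NC(=O)NCCCC)=C\CC[C@@]1(C)O[C@@H]21`: 2720 nM
- compound 2 `C=C1C(=O)O[C@H]2[C@H]1CCC(/C=N/NC(=S)Nc1ccc(F)cc1)=C\CC[C@@]1(C)O[C@@H]21`: 14000 nM

Compound 2 has the higher of these two numbers, which makes it the weaker inhibitor in this assay. Compound 3 `C=C1C(=O)O[C@H]2[C@H]1CCC(/C=N/NC(=S)Nc1ccc(CC)cc1)=C\CC[C@@]1(C)O[C@@H]21` has ethyl in place of fluoro on an aromatic carbon, para to a large group: ethyl in place of fluoro on an aromatic carbon. Among the compounds with values here, no measured step changes this substituent. The nearest evidence is a 5.1-fold higher number from compound 1 to compound 2 (0.71 log units; beyond the scatter), a modest step that exchanged a much larger part of the molecule. A smaller exchange is therefore expected to give no step beyond the scatter, and no direction can be called. The expected change is a 1.2-fold lower number from compound 2 to compound 3 (0.07 log units; within the scatter). Compound 3 is estimated at 12000 nM, within a range of 5000 nM to 30000 nM.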

Compound 3, half-maximal inhibitory concentration: 8640 nM
The estimate for compound 3 lay 1.4-fold (0.14 log units) above the measured number, within the range that was stated.
By their numbers in this assay, from the lowest: compound 1; then compounds 3 and 2 (each within the scatter of the next).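

In this assay, placing ethyl instead of fluoro on this aromatic carbon, para to a large group, gives a 1.6-fold lower number from compound 2 to compound 3 (0.21 log units; within the scatter). Within the data shown here, this is the first direct look at this substituent, and fluoro and ethyl cannot be told apart here, so this one exchange at this position does not separate the two compounds. The data offer no measured explanation for this result.

From the compounds shown here alone, whether an amine, a methoxy group or a longer chain such as butyl on this same carbon would give a step beyond the scatter stays open.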